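The compounds below may be only part of what the source reports. "The series", "measured", "known", "first", "only" and "open" are said of these compounds alone.

Among the measured compounds shown here, in a functional assay on XF498 cells (Homo sapiens) for cytotoxicity (on this read-out higher numbers stand for weaker inhibition and lower numbers for stronger inhibition), two compounds on a shared core carry numbers so far. Compound 1 `Cc1ccc2c(S)nc(-c3ccccc3)cc2c1` gives 9120 nM; 75900 nM (2 entries), so its two entries stand well apart. Compound 2 `COc1ccc(-c2cc3cc(C)ccc3c(N3CCN(C)CC3)n2)cc1` gives 7410 nM, the only number shown for it, and one further entry for compound 2 offers no single number. Compound 3 `Cc1ccc2c(N3CCN(C)CC3)nc(-c3ccc(Cl)cc3)cc2c1` has not yet been measured. It differs from compound 2 by one change, chloro in place of methoxy on an aromatic carbon, para to a large group: chloro in place of methoxy on an aromatic carbon. For the measured compounds named here, no measured pair shows what this swap does in this assay, and the remaining evidence is thin: the several entries of compound 1 in this assay, 9120 nM; 75900 nM (2 entries). The estimate therefore rests on compound 2 at 7410 nM. The expected step of a 1.1-fold lower number from compound 2 to compound 3 (0.02 log units; within the scatter) is estimated to stay within the scatter, with neither direction favoured. Compound 3 is expected at 7000 nM, with an estimated range of 2500 nM to 20000 nM.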

Compound 3, half-maximal inhibitory concentration: 4070 nM
The estimate for compound 3 lay 1.7-fold (0.24 log units) above the measured number; the measured number falls inside the stated range.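

The pair of compound 2 and compound 3 is the only one shown that reads this change directly. In this assay, chloro in place of methoxy on an aromatic carbon, para to a large group, gives a 1.8-fold lower number from compound 2 to compound 3 (0.26 log units; within the scatter), so the swap from 4-methoxyphenyl to 4-chlorophenyl cannot be told apart from repeat variation in this single pair. The result must also be read against how far repeated entries can lie apart on the shared core: the several entries of compound 1 in this assay, 9120 nM; 75900 nM (2 entries)

The compounds shown leave open whether any group at this position moves the number beyond the scatter, for instance an amine, a carboxylic acid or a longer chain such as butoxy. With a single pair, they also leave open whether chloro in place of methoxy would behave the same way elsewhere on the shared core.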